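Cytotoxicity notes: trifluoromethyl in place of methoxy

The source may hold more compounds than are shown below. What is called first, only, known or untested is meant among the compounds shown, and "the series" means these compounds.

Among the measured compounds shown here, compound 1 (`COc1cccc(-c2cc(=O)c3cc(NC(C)=O)ccc3o2)c1`) holds the only actual number so far: in an ADME assay on THP-1 cells (Homo sapiens) for cytotoxicity, read by flow cytometry and propidium iodide staining, with a stated time of 72 h (on this read-out higher numbers stand for weaker inhibition and lower numbers for stronger inhibition), compound 1 gives 10000 nM. Compound 2 (`CC(=O)Nc1ccc2oc(-c3ccccc3F)cc(=O)c2c1`) gives only a limit in this assay, reported as > 125000 nM. That reading is a limit of the assay and not a number, so the series rests on the limit of > 125000 nM in this assay, at which 1 of the 2 values shown sits, and offers no second figure for comparison.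

Next in line is compound 3 (`CC(=O)Nc1ccc2oc(-c3cccc(C(F)(F)F)c3)cc(=O)c2c1`), which carries trifluoromethyl in place of methoxy on an aromatic carbon, meta to a large group: trifluoromethyl in place of methoxy on an aromatic carbon. For the measured compounds named here, no measured pair shows this change or any other single-place change, so the expectation is only loosely anchored on compound 1 at 10000 nM. A modest move toward weaker inhibition seems the likelier direction, with a real chance that the reading ends up as a limit rather than a number.

The expected step in this assay is a 2.5-fold higher number from compound 1 to compound 3 (0.40 log units; beyond the scatter), only a little beyond the scatter. For compound 3 the estimated value is 25000 nM, with an expected range of 7000 nM to 100000 nM.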

Compound 3, half-maximal inhibitory concentration: 50000 nM
Beside the measured number, compound 3's estimate is 2.0-fold (0.30 log units) below it; the measured number falls inside the stated range.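

Trifluoromethyl in place of methoxy on an aromatic carbon, meta to a large group, gives a 5.0-fold higher number from compound 1 to compound 3 (0.70 log units; beyond the scatter) in this assay and provides the first single-place step that can be read in this series. The change moves toward weaker inhibition and lies beyond the scatter, so in this one pair, the reading responds to the group carried at this position. Compound 2 remains a limit of the assay and not a number, so it adds no second figure on this change: the limit of > 125000 nM in this assay, at which 1 of the 3 values shown sits.

With a single pair, the step cannot be assigned to the loss of methoxy or to the arrival of trifluoromethyl, and it supports no general trend across the series. The compounds shown leave open how an amine, a carboxylic acid or a longer alkoxy chain would read at this position in this assay, and whether trifluoromethyl would give a step of similar size and direction on a different aromatic carbon of the same ring.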